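The compounds below may be only part of what the source reports. "The series", "measured", "known", "first", "only" and "open" are said of these compounds alone.

The measured compounds and their values:

Compound 1, `Nc1cc(N)c2nc(-c3ccccc3)c(Sc3ccc(F)cc3)nc2c1`: 16600 nM
Compound 2, `COc1cc(CNc2nc3cc(N)cc(N)c3nc2-c2ccccc2)cc(OC)c1OC`: 17000 nM
Compound 3, `CCOC(=O)[C@H](CCC(=O)O)NC(=O)c1ccc(CNc2nc3cc(N)cc(N)c3nc2-c2ccccc2)cc1`: < 100000 nM

In a functional assay on HOP-62 cells (Homo sapiens) for inhibition, read by sulforhodamine B assay, with a stated time of 48 h (a lower number here means a stronger inhibitor of growth, a higher number a weaker inhibitor of growth), compound 1 gives 16600 nM. Among the two plain numbers available, compound 1 stands lowest, but its nearest neighbour, compound 2, gives 17000 nM, which is within the scatter of compound 1, so the two cannot be placed in order. Compound 3 reaches only a limit of this assay, < 100000 nM, and no number is known for it; this is the limit of < 100000 nM in this assay, at which 1 of the 3 values shown sits.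

Compound 4, `Nc1cc(N)c2nc(-c3ccccc3)c(NCc3ccc(F)cc3)nc2c1`, has not yet been measured in this assay. It differs from compound 1 as follows: (4-fluorobenzyl)amino in place of (4-fluorophenyl)sulfanyl on an aromatic carbon. Compound 2 already carries a benzylamino-type group at the same place and gives a value within the scatter of compound 1, so the change is expected to alter the number little. The step of a 1.0-fold lower number from compound 1 to compound 4 (0.02 log units; within the scatter) is therefore expected to lie within the scatter, with no clear direction. Compound 4 is estimated at 16000 nM, in the range 5000 nM to 60000 nM.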

Compound 4, concentration for 50% growth inhibition: 38900 nM
The estimate for compound 4 lay 2.4-fold (0.39 log units) below the measured number; measured number inside the range.
By their numbers in this assay, from the lowest: compounds 1 and 2 (each within the scatter of the next); then compound 4.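

In this assay, for the compounds shown here, the first comparison that changes only the group on this aromatic carbon, next to the ring nitrogen, gives a 2.3-fold higher number from compound 1 to compound 4 (0.37 log units; beyond the scatter), so the number responds to this change, though modestly. The change replaces (4-fluorophenyl)sulfanyl with (4-fluorobenzyl)amino, which alters the atom attached to the ring and the length of the link to the fluorophenyl ring together, and adds a hydrogen-bond donor, so this single step cannot assign the shift to any one of these differences. Nothing in the data shown explains the shift.

Going by these compounds, it remains open how a (4-fluorophenyl)amino or a (4-fluorobenzyl)sulfanyl group at the same carbon would read, and either could help separate the linking atom from the link length. Also open, on these data alone, is how a much smaller group, such as a plain amine or a methoxy, would read there.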